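Swapping the 5-nitrothiophen-3-yl group of compound 3

A few compounds are considered here, and "the series" means these few. Any claim that something is new, unique, unknown or untested is made for them only; others in the source may bear on it.

In a functional assay on Caco-2 cells (Homo sapiens) for inhibition, read by MTT assay, with a stated time of 48 h, tested at 10 uM (on this read-out lower numbers stand for less inhibition of growth and higher numbers for more inhibition of growth at the one concentration tested), compound 3 (`Cc1oc2c([C@H]3CCN(C)C[C@H]3O)c(O)cc(O)c2c(=O)c1C(O)c1csc([N+](=O)[O-])c1`) gives 3% and stands level with compound 1 (`Cc1oc2c([C@H]3CCN(C)C[C@H]3O)c(O)cc(O)c2c(=O)c1C(O)c1cccc(Cl)c1`) at 4% on the shared core, while compound 2 (`Cc1oc2c([C@H]3CCN(C)C[C@H]3O)c(O)cc(O)c2c(=O)c1C(O)c1c(Cl)cccc1Cl`) gives 24% and stands clearly apart. Compound 4 (`Cc1oc2c([C@H]3CCN(C)C[C@H]3O)c(O)cc(O)c2c(=O)c1C(O)c1ccc(F)cc1`) differs from compound 3 by 4-fluorophenyl in place of 5-nitrothiophen-3-yl on a saturated chain carbon bound to an aromatic carbon and an oxygen on a saturated carbon in one place: 4-fluorophenyl in place of 5-nitrothiophen-3-yl on a saturated chain carbon bound to an aromatic carbon and an oxygen on a saturated carbon. All three measured steps fall at that same carbon. One exchange of groups there left the number within the scatter, namely a number 1 percentage points lower from compound 1 to compound 3 (within the scatter) (5-nitrothiophen-3-yl in place of 3-chlorophenyl). The only modest moves, a number 20 percentage points higher from compound 1 to compound 2 (beyond the scatter) and a number 21 percentage points lower from compound 2 to compound 3 (beyond the scatter), both involve the 2,6-dichlorophenyl group of compound 2, which compound 4 does not carry. Three compounds are a thin basis, but no step beyond the scatter is expected. The estimated change is a number 4 percentage points higher from compound 3 to compound 4 (within the scatter) and lies within the scatter. Compound 4 is expected at 7% with a range from 0% to 20% in this estimate.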

Compound 4, percent growth inhibition at one concentration: 11%
For compound 4 the middle estimate is 4 percentage points below the measured one; low and high end bracket the measured number.
By their numbers in this assay, from the lowest: compounds 3, 1 and 4 (each within the scatter of the next); then compound 2.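

In this assay, the 4-fluorophenyl group joins the 3-chlorophenyl and 5-nitrothiophen-3-yl groups as a third group at this carbon that stays within the scatter of the others: a number 8 percentage points higher from compound 3 to compound 4 (within the scatter) and a number 7 percentage points higher from compound 1 to compound 4 (within the scatter). Compound 2 now also stands apart from a third partner, a number 13 percentage points lower from compound 2 to compound 4 (beyond the scatter), so among the four groups shown, only exchanges involving the 2,6-dichlorophenyl group give steps beyond the scatter. Nothing available explains why this group stands apart.

The compounds shown leave open whether a group without an aromatic ring, such as cyclohexyl, or a basic one, such as an aminomethyl chain, would stay level with compound 4 or move as far as compound 2. They also leave open how a pyridyl ring would read at this carbon.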